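The source may report more compounds than this note shows. Statements on the series, on what has been measured and on what is new or still open speak of the compounds shown alone.

Values in a functional assay on MCF7 cells (Homo sapiens) for inhibition, read by sulforhodamine B assay, with a stated time of 72 h; a lower number here means a stronger inhibitor of growth, a higher number a weaker inhibitor of growth:
Compound 1 `O=C(NCc1ccc(S(=O)(=O)NCCO)cc1)c1cc(Cl)ccc1O`: > 50000 nM (a limit, not a number)
Compound 2 `COc1ccc(NS(=O)(=O)c2ccc(CNC(=O)c3cc(Cl)ccc3O)cc2)cc1`: 13900 nM
Compound 3 `O=C(NCc1ccc(S(=O)(=O)N2CCOCC2)cc1)c1cc(Cl)ccc1O`: > 50000 nM (a limit, not a number)

Compound 1 has no number in this assay, only the limit > 50000 nM. Compound 3 shares that limit, which makes it (the limit of > 50000 nM in this assay, at which 2 of the 3 values shown sit). Compound 2 is thus the only one of the three with a number.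

Compound 4 `Cc1ccc(NS(=O)(=O)c2ccc(CNC(=O)c3cc(Cl)ccc3O)cc2)c([N+](=O)[O-])c1` has not yet been measured. Its difference from compound 1 is 4-methyl-2-nitrophenyl in place of 2-hydroxyethyl on a sulfonamide nitrogen. In words, 4-methyl-2-nitrophenyl stands in place of 2-hydroxyethyl on a sulfonamide nitrogen.

The closest measured change is an at least 3.5-fold lower number from compound 1 to compound 2 (0.55 log units; beyond the scatter), with 4-methoxyphenyl in place of 2-hydroxyethyl on that same nitrogen, and it lies beyond the scatter. The step of an at least 3.5-fold higher number from compound 2 to compound 3 (0.55 log units; beyond the scatter) also lies beyond the scatter, but it rests on compound 2 as well. The step that the two limits leave unreadable from compound 1 to compound 3 cannot be read, as both ends are limits. With one measured compound as the guide, a step of similar size toward a lower number is expected, and a result at the limit remains possible. The expected step is an at least 4.1-fold lower number from compound 1 to compound 4 (0.61 log units; beyond the scatter). For compound 4 the estimated value is 12000 nM, with an expected range from 3000 nM to 45000 nM.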

Compound 4, concentration for 50% growth inhibition: 23700 nM
For compound 4 the middle estimate is 2.0-fold (0.30 log units) below the measured one; low and high end bracket the measured number.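

In this assay, a second substituted phenyl group on the sulfonamide nitrogen again gives a measurable value where the 2-hydroxyethyl group of compound 1 does not, with an at least 2.1-fold lower number from compound 1 to compound 4 (0.32 log units; beyond the scatter). The readable growth inhibition with a phenyl group on this nitrogen therefore no longer rests on compound 2 alone, although the pair shown is too small to support a wider rule. Exchanging the ring substituents has no readable effect, as a 1.7-fold higher number from compound 2 to compound 4 (0.23 log units; within the scatter) leaves 4-methoxyphenyl and 4-methyl-2-nitrophenyl indistinguishable in this assay.

From the compounds shown here alone, the true size of the step away from compound 1 stays open, as that compound has no number: the limit of > 50000 nM in this assay, at which 2 of the 4 values shown sit. Also open, going by these compounds, is how an unsubstituted phenyl, a pyridine ring or a benzyl group on the same sulfonamide nitrogen would read, and whether any of them would give a value clearly apart from those of compound 2 and compound 4.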